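Isopropyl on the open-chain urea of compound 2

The source may report more compounds than this note shows. Statements on the series, on what has been measured and on what is new or still open speak of the compounds shown alone.

In a functional assay on the whole organism for inhibition, with Mus musculus as the target, with a stated time of 90 s (a lower number here means that less compound is needed, a higher number that more compound is needed for the effect), compound 1 (`CC(C)N1CCN(CCN2CCC(c3cn(-c4ccc(F)cc4)c4cc(Cl)ccc34)CC2)C1=O`) gives 2.3 umol/kg as a measured number. Compound 2 (`CNC(=O)N(C)CCN1CCC(c2cn(-c3ccc(F)cc3)c3cc(Cl)ccc23)CC1`) gives > 23 umol/kg which is a limit of the assay and not a number. Compound 3 (`CC(C)NC(=O)N(C)CCN1CCC(c2cn(-c3ccc(F)cc3)c3cc(Cl)ccc23)CC1`) has isopropyl in place of methyl on an amide-type nitrogen. Within the data shown here, the only measured step bearing on this is large (an at least 10-fold higher number from compound 1 to compound 2 (1.00 log units; beyond the scatter)) and it also removed the isopropyl of compound 1. A partial return towards compound 1 is therefore expected, meaning a lower number in this assay (an at least 2.3-fold lower number from compound 2 to compound 3 (0.36 log units; beyond the scatter)) as an estimated step. Compound 3 is estimated at 10 umol/kg with an expected range of 2.5 umol/kg to 40 umol/kg in these notes.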

Compound 3, dose for half-maximal effect: > 21 umol/kg
Compound 3 was reported as a limit; the forecaster's own chance of this, stated with the estimate: 35%; middle value at least 2.1-fold (0.32 log units) away from the limit.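

In this assay, compound 3 gives > 21 umol/kg, which is a limit of the assay and not a number. Both values for the methyl and isopropyl open-chain ureas are limits, so the step between them cannot be read. With isopropyl on the amide-type nitrogen, the open-chain urea still shows an at least 9.1-fold higher number from compound 1 to compound 3 (0.96 log units; beyond the scatter), so carrying an isopropyl does not by itself match the 3-isopropyl-2-oxoimidazolidin-1-yl group.

Open, as far as these compounds go, is whether the ring matters independently of its isopropyl, which a 3-methyl-2-oxoimidazolidin-1-yl group could test. Also open, from the compounds shown here alone, is whether cyclopentyl or a longer chain on the amide-type nitrogen would give a measurable value in this assay.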